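Swapping Chloro for Phenyl on the Core of Compound 1

The compounds below may be only part of what the source reports. "The series", "measured", "known", "first", "only" and "open" are said of these compounds alone.

Compound 1 `O=C(NCCCCc1ccccc1)n1c(=O)oc2cc(Cl)ccc21`: 33 nM
Compound 2 `COc1ccc(CCCCNC(=O)n2c(=O)oc3ccccc32)cc1`: 63 nM
Compound 3 `O=C(NCCCCc1ccccc1)n1c(=O)oc2cc(Cl)c(Cl)cc21`: 18 nM

Of the compounds shown here, three have been tested in an assay on HEK293 cells for inhibition of acid ceramidase (Homo sapiens), with a stated time of 10 min; a lower number here means a stronger inhibitor, a higher number a weaker inhibitor. Compound 1 gives 33 nM, the second highest of the three numbers; compound 3 gives 18 nM and compound 2 gives 63 nM, and both differences from compound 1 fall within the scatter. For the measured compounds named here, the only measured single change is a 1.8-fold lower number from compound 1 to compound 3 (0.26 log units; within the scatter). Compound 4 `O=C(NCCCCc1ccccc1)n1c(=O)oc2cc(-c3ccccc3)ccc21` differs from compound 1 by phenyl in place of chloro on an aromatic carbon. Going by the values given here, no measured step exchanges chloro for phenyl, so the expectation rests on the step from compound 1 to compound 3 having stayed within the scatter. Compound 4 is therefore expected to show a 1.2-fold higher number from compound 1 to compound 4 (0.08 log units; within the scatter). The estimate for compound 4 in this assay is 40 nM, ranging from 12 nM to 130 nM.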

Compound 4, half-maximal inhibitory concentration: 84 nM
The estimate for compound 4 lay 2.1-fold (0.32 log units) below the measured number; measured number inside the range.
By their numbers in this assay, from the lowest: compounds 3, 1, 2 and 4 (each within the scatter of the next, the first and the last beyond it).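

In this assay, for the compounds shown here, phenyl in place of chloro gives a 2.5-fold higher number from compound 1 to compound 4 (0.41 log units; beyond the scatter), the first single change here to go beyond the scatter. The step is modest, so this position on the core still carries an inhibitor when one chlorine atom gives way to an aromatic ring of six heavy atoms, though the number rises. Nothing available explains this rise. As far as these compounds go, whether a small fluoro, an amine or a carboxylic acid at this position would keep the number near that of compound 1 remains open.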